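Sulfanyl in place of methylsulfanyl on the shared core

A few compounds are considered here, and "the series" means these few. Any claim that something is new, unique, unknown or untested is made for them only; others in the source may bear on it.

Measured compounds and their values in a functional assay for inhibition, with Homo sapiens as the target; on this read-out lower numbers stand for stronger inhibition and higher numbers for weaker inhibition:
- compound 1 `CCc1nc(C)c2cnnc(SC)n12`: > 48000 nM, a limit of the assay
- compound 2 `CCCc1nc(C)c2cnnc(SC)n12`: > 48000 nM, a limit of the assay
- compound 3 `CSc1nncc2c(C)ncn12`: > 48000 nM, a limit of the assay

Compound 1 stands only at a limit of this assay, with no number of its own. The same holds for the other two measured compounds, as the limit of > 48000 nM in this assay, at which 3 of the 3 values shown sit, shows. The measured steps therefore read nothing: a step that the two limits leave unreadable from compound 1 to compound 2, a step that the two limits leave unreadable from compound 1 to compound 3 and a step that the two limits leave unreadable from compound 2 to compound 3 are all bracketed by limits on both sides.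

Compound 4 `CCc1nc(C)c2cnnc(S)n12` is the next member; it differs from compound 1 by hydrogen in place of methyl on a sulfur. Going by the values given here, no measured step touches the sulfur, and the steps that are measured are unreadable, so no direction or size of the change can be drawn from them. Compound 1 is at the limit, and the step from compound 1 to compound 4 is expected to be a step that the limit leaves unreadable from compound 1 to compound 4, meaning no reading beyond the scatter can be predicted. Compound 4 is expected to give about 60000 nM in this assay, in the range 10000 nM to 300000 nM, most likely reported again as a limit.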

Compound 4, half-maximal inhibitory concentration: > 48000 nM
Compound 4: no number, only a limit (the forecaster's own chance of this, stated with the estimate: 80%); the middle value is on the limit's open side.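

In this assay compound 4 gives > 48000 nM, a limit, so the change from compound 1 to compound 4 cannot be read: the limit of > 48000 nM in this assay, at which 4 of the 4 values shown sit.

The compounds shown leave open whether methylsulfanyl and sulfanyl differ at all in this assay, and what number any of these compounds would have.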